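Acylation of the ring nitrogen in the para-hydroxyphenyl amide

The source may hold more compounds than are shown below. What is called first, only, known or untested is meant among the compounds shown, and "the series" means these compounds.

Working notes. The series shares a fused bicyclic amine core carrying an anilide. Compound 1 `O=C(Nc1ccccc1O)C1c2ccccc2CCN1C(=O)c1ccc(Cl)cc1` bears an ortho-hydroxy anilide and a (4-chlorophenyl)carbonyl on the ring nitrogen; in a functional assay on NUGC-3 cells (Homo sapiens) for inhibition, read by sulforhodamine B assay, with a stated time of 48 h (a lower number here means a stronger inhibitor of growth, a higher number a weaker inhibitor of growth), compound 1 reaches only the assay limit, > 10000 nM, which is a limit and not a number. Among the compounds with values here, compound 2 `COc1ccccc1NC(=O)C1c2ccccc2CCN1C(=O)c1ccc(Cl)cc1` differs by methyl on the phenolic oxygen and in this assay compound 2 gives 1590 nM; the step of an at least 6.2-fold lower number from compound 1 to compound 2 (0.79 log units; beyond the scatter) is the only measured step. Compound 3 `O=C(Nc1ccc(O)cc1)C1NCCc2ccccc21` carries the para-hydroxy anilide on the free secondary amine; in this assay compound 3 gives 4370 nM, the higher of the two numbers, compound 2 standing lower.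

Compound 4 `O=C(Nc1ccc(O)cc1)C1c2ccccc2CCN1C(=O)c1ccc(Cl)cc1` is to be measured. The change is (4-chlorophenyl)carbonyl in place of hydrogen on an amine nitrogen in a ring. Within the data shown here, no measured step covers this change: the only step, an at least 6.2-fold lower number from compound 1 to compound 2 (0.79 log units; beyond the scatter), concerns the phenolic oxygen, and the one value at the limit, (the limit of > 10000 nM in this assay, at which 1 of the 3 values shown sits), belongs to a differently substituted anilide. The size of the step is therefore open. Compounds 2 and 4 carry the same ring-nitrogen acyl group, so a number near that of compound 2 is expected for compound 4, a modest fall a 1.7-fold lower number from compound 3 to compound 4 (0.24 log units; within the scatter) with a wide range. Compound 4 is estimated at 2500 nM, between 500 nM and 15000 nM.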

Compound 4, concentration for 50% growth inhibition: > 10000 nM
Compound 4: only a limit was reported; the forecaster's own chance of this, stated with the estimate: 25%; middle value at least 4.0-fold (0.60 log units) from the limit.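

In this assay, adding the (4-chlorophenyl)carbonyl on the amine nitrogen in the ring to the 4-hydroxyphenyl amide does not strengthen growth inhibition: the change gives an at least 2.2-fold higher number from compound 3 to compound 4 (0.35 log units; beyond the scatter). With that acyl group kept in place, the group on the amide-type nitrogen matters, since 4-hydroxyphenyl in place of 2-methoxyphenyl gives an at least 6.2-fold higher number from compound 2 to compound 4 (0.79 log units; beyond the scatter). Compound 1 and compound 4 both stand at a limit, so the step between them cannot be read: the limit of > 10000 nM in this assay, at which 2 of the 4 values shown sit.

The compounds shown leave open how a 4-methoxyphenyl amide would read with the same acyl group, which would separate the place of the oxygen from the methyl on it. Also open, on these data alone, is whether a smaller group on the ring nitrogen, such as acetyl or benzyl, would read closer to the free amine.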